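Moving the Chlorine on Compound 2

This account rests on a few compounds, and the source may have more. Where it says the series, first, only, none or still open, it means among the compounds named here.

In a functional assay on NCI-H23 cells (Homo sapiens) for cytotoxicity, read by sulforhodamine B assay, with a stated time of 72 h (on this read-out higher numbers stand for weaker inhibition of growth and lower numbers for stronger inhibition of growth), compound 1 `CC(=O)N1c2ccccc2CCC1C(=O)Nc1ccccc1O` gives 65700 nM.
In this assay compound 2 `O=C(Nc1ccccc1O)C1CCc2ccccc2N1C(=O)c1ccccc1Cl` gives 46900 nM.
Compound 3 `O=C(Nc1ccccc1C(F)(F)F)c1ccc2ccccc2n1` reaches only the limit of this assay, reported as > 90000 nM.

Among the two numbers, compound 2 sits lowest, with compound 1 nearest to it; the single step with both ends measured, a 1.4-fold lower number from compound 1 to compound 2 (0.15 log units; within the scatter), falls within the scatter of this assay, so the two cannot be told apart. Compound 3 gives no number at all, only a limit, (the limit of > 90000 nM in this assay, at which 1 of the 3 values shown sits).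

Compound 4 `O=C(Nc1ccccc1O)C1CCc2ccccc2N1C(=O)c1ccc(Cl)cc1` is the next compound in line. It is built from the same atoms as compound 2 and differs only in this: 4-chlorophenyl in place of 2-chlorophenyl on a carbonyl carbon. Among the measured compounds shown here, no measured step moves a chlorine from one position of the ring to another, so nothing measured bears on this change directly. For the measured compounds named here, the one measured step, a 1.4-fold lower number from compound 1 to compound 2 (0.15 log units; within the scatter), exchanged a methyl for a 2-chlorophenyl on the same carbonyl carbon and stayed within the scatter, which gives no sign that this carbonyl substituent drives the read-out.

Compound 4 is therefore expected to stay close to compound 2, with a step of a 1.1-fold higher number from compound 2 to compound 4 (0.03 log units; within the scatter). The estimate for compound 4 is 50000 nM, with a range from 20000 nM to 110000 nM.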

Compound 4, concentration for 50% growth inhibition: 19200 nM
Estimate against measurement, compound 4: 2.6-fold (0.42 log units) above, outside the stated range (below it).
By their numbers in this assay, from the lowest: compound 4; then compounds 2 and 1 (each within the scatter of the next). At a limit, above all of these: compound 3.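

In this assay, the place of the chlorine on the ring carried by the carbonyl carbon now shows up in the read-out: a 2.4-fold lower number from compound 2 to compound 4 (0.39 log units; beyond the scatter), is a step beyond the scatter and the first sign that this substituent on the amide-type nitrogen of the shared core matters at all, though only modestly. Set against the methyl, the two chlorophenyl groups do not read alike, since a 3.4-fold lower number from compound 1 to compound 4 (0.53 log units; beyond the scatter), also lies beyond the scatter, while a 1.4-fold lower number from compound 1 to compound 2 (0.15 log units; within the scatter), does not, so a chlorophenyl at this carbonyl carbon is not enough by itself and the outcome depends on which chlorophenyl it is. Nothing in the data at hand accounts for this difference between 4-chlorophenyl and 2-chlorophenyl.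

The compounds shown leave open whether the chlorine itself contributes or only its place on the ring, a question that a plain phenyl, or an amine or a carboxylic acid in place of the chlorine, would bear on. They also leave open whether 3-chlorophenyl would read with 2-chlorophenyl, with 4-chlorophenyl or apart from both.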